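A few compounds are considered here, and "the series" means these few. Any claim that something is new, unique, unknown or untested is made for them only; others in the source may bear on it.

- Compound 1 `Nc1ncnc2c1ncn2[C@H]1C=C[C@@H](COP2(=O)OCc3ccccc3O2)O1`: 10.3 h
- Compound 2 `Cc1cc(C)c2c(c1)COP(=O)(OC[C@@H]1C=C[C@H](n3cnc4c(N)ncnc43)O1)O2`: 44.7 h

These two compounds have been compared in an ADME assay for metabolic stability, in phosphate buffer, at pH 7.3; on this read-out lower numbers stand for a shorter-lived compound and higher numbers for a longer-lived compound. Compound 2 stands highest at 44.7 h, and compound 1 gives 10.3 h, a gap beyond the usual scatter of repeated measurements.

The next compound to be measured is compound 3 `Cc1cccc2c1OP(=O)(OC[C@@H]1C=C[C@H](n3cnc4c(N)ncnc43)O1)OC2`. It differs from compound 2 in one place: hydrogen in place of methyl on an aromatic carbon. In words, this is hydrogen in place of methyl on an aromatic carbon. Within the data shown here, no measured pair shows this single change on its own, so the expectation rests on only two values. In structure, compound 3 lies between compound 2 and compound 1, which has no methyl groups. With compound 1 at 10.3 h as the lower reference, a value for compound 3 between the two measured numbers seems likely. The expected change is a 1.9-fold lower number from compound 2 to compound 3 (0.27 log units; within the scatter), a drop close to the edge of the scatter. The estimated half-life of compound 3 is 24 h, with an expected range of 13 h to 42 h.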

Compound 3, half-life in the ADME assay: 32.3 h
The estimate for compound 3 lay 1.3-fold (0.13 log units) below the measured number, within the range that was stated.
By their numbers in the ADME assay, from the lowest: compound 1; then compounds 3 and 2 (each within the scatter of the next).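

The methyl at this position, meta to a methyl group and para to a fused ring, carries little weight in the ADME assay: the result is a 1.4-fold lower number from compound 2 to compound 3 (0.14 log units; within the scatter), so the two compounds cannot be told apart on this read-out. The single methyl that remains counts for more, with a 3.1-fold higher number from compound 1 to compound 3 (0.50 log units; beyond the scatter), so in this short series one methyl group on the ring is enough to give a longer-lived compound. In a physicochemical assay for lipophilicity (a lower number here means a more polar compound, a higher number a more lipophilic compound), compound 2 gives 0.95 and compound 3 gives 0.63. Hydrogen in place of methyl does register in the physicochemical assay, where the compound becomes modestly more polar: the measured partition coefficient of compound 2, 0.95, and of compound 3, 0.63, a number 0.32 log units lower (beyond the scatter)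

Going by these compounds, what a different group at this position, such as a chlorine atom or a methoxy group, would do to the half-life remains open. Two compounds also cannot settle whether the numbers in the ADME assay follow those in the physicochemical assay more widely, since a single step gives no trend.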